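The source may report more compounds than this note shows. Statements on the series, on what has been measured and on what is new or still open speak of the compounds shown alone.

The measured compounds are:
Compound 1, `Cn1ccc2ccc(-c3cc(Nc4cnccc4C(=O)NCc4cncnc4)cc4nccnc34)cc21`: 106 nM in an assay for inhibition of 6-phosphofructo-2-kinase/fructose-2,6-bisphosphatase 3 (Homo sapiens), read by ADP-Glo, with a stated time of 2 h; on this read-out higher numbers stand for weaker inhibition and lower numbers for stronger inhibition
Compound 2, `CN1CCC(NC(=O)c2ccncc2Nc2cc(-c3ccc4ccn(C)c4c3)c3nccnc3c2)CC1`: 38 nM in this assay
Compound 3, `CC(=O)N1CCOC(CNC(=O)c2ccncc2Nc2cc(-c3ccc4ccn(C)c4c3)c3nccnc3c2)C1`: 93 nM in this assay

Compound 3 stands at the second highest of the three numbers. Against compound 1 it is indistinguishable, the step being a 1.1-fold lower number from compound 1 to compound 3 (0.06 log units; within the scatter); against compound 2 it sits apart, the step being a 2.4-fold higher number from compound 2 to compound 3 (0.39 log units; beyond the scatter).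

Compound 4, `CC(=O)N1CC(CNC(=O)c2ccncc2Nc2cc(-c3ccc4ccn(C)c4c3)c3nccnc3c2)C1`, differs from compound 3 in one place: 1-acetylazetidin-3-yl in place of 4-acetylmorpholin-2-yl on a saturated chain carbon bound to an amide-type nitrogen. Going by the values given here, no measured step repeats this exchange. Among the compounds with values here, the steps that bear on it are the three that swap the group carried by the amide-type nitrogen: a 2.8-fold lower number from compound 1 to compound 2 (0.45 log units; beyond the scatter), a 1.1-fold lower number from compound 1 to compound 3 (0.06 log units; within the scatter) and a 2.4-fold higher number from compound 2 to compound 3 (0.39 log units; beyond the scatter). All of them are modest or within the scatter, so the three groups tried so far on that nitrogen spread the numbers in this assay over only a narrow band.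

On that basis compound 4 is expected to stay close to compound 3, with a step of a 1.1-fold higher number from compound 3 to compound 4 (0.03 log units; within the scatter) expected in this assay, not beyond the scatter in either direction. The estimate for compound 4 in this assay is 100 nM, expected to fall between 40 nM and 250 nM.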

Compound 4, half-maximal inhibitory concentration: 137 nM
The estimate for compound 4 lay 1.4-fold (0.14 log units) below the measured number; low and high end bracket the measured number.
By their numbers in this assay, from the lowest: compound 2; then compounds 3, 1 and 4 (each within the scatter of the next).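

In this assay, the exchange at this place, on a saturated chain carbon bound to an amide-type nitrogen, replaces a six-membered ring with 2 hetero atoms by a four-membered ring with 1 hetero atom, yet the two compounds cannot be told apart (a 1.5-fold higher number from compound 3 to compound 4 (0.17 log units; within the scatter)). Going by these compounds alone, the 1-acetylazetidin-3-yl compound also cannot be told apart from the pyrimidin-5-yl compound (a 1.3-fold higher number from compound 1 to compound 4 (0.11 log units; within the scatter)), so three quite different groups at this place now share one band, while the 1-methylpiperidin-4-yl group on the amide-type nitrogen stands apart from all of them, with the largest step so far (a 3.6-fold higher number from compound 2 to compound 4 (0.56 log units; beyond the scatter)). Nothing given here accounts for these numbers.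

The compounds shown leave open whether the separate standing of compound 2 goes with the methyl rather than acetyl on the ring nitrogen, with the six-membered ring, or with the absence of the chain carbon, as these features are not varied one at a time. A 1-acetylpiperidin-4-yl group and a (1-methylpiperidin-4-yl)methyl group on the same nitrogen would each separate these features.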